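The source may hold more compounds than are shown below. What is called first, only, known or untested is meant among the compounds shown, and "the series" means these compounds.

Series notes. Compound 1 `Cn1cccc1C(=O)/C=C/c1ccc2c(c1)B(O)OC2` gives in a functional assay on HCT-116 cells (Homo sapiens) for cytotoxicity, read by MTT assay, with a stated time of 48 h (on this read-out lower numbers stand for stronger inhibition and higher numbers for weaker inhibition), only a limit, > 100000 nM. Compound 2 `O=C(/C=C/c1ccc2c(c1)B(O)OC2)c1ccc(I)cc1` gives 11600 nM in this assay. Compound 3 `Nc1ccc(C(=O)/C=C/c2ccc3c(c2)B(O)OC3)cc1` gives 26100 nM in this assay, the higher of the two numbers, with the step of a 2.3-fold higher number from compound 2 to compound 3 (0.35 log units; beyond the scatter) setting it apart. The steps of an at least 8.6-fold lower number from compound 1 to compound 2 (0.93 log units; beyond the scatter) and an at least 3.8-fold lower number from compound 1 to compound 3 (0.58 log units; beyond the scatter) exchange the group on the carbonyl carbon and run from a limit. Compound 4 `COc1cc(C(=O)/C=C/c2ccc3c(c2)B(O)OC3)ccc1N` is not yet measured; it differs from compound 3 by methoxy in place of hydrogen on an aromatic carbon. For the measured compounds named here, no measured step adds a methoxy, and only the amino-for-iodo exchange touches this ring, so no strong pull in either direction is expected in this assay. The step of a 1.3-fold lower number from compound 3 to compound 4 (0.12 log units; within the scatter) is expected to stay near the scatter. Compound 4 is estimated at 20000 nM, with a range of 7000 nM to 60000 nM.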

Compound 4, half-maximal inhibitory concentration: 27900 nM
Compound 4: middle estimate off by 1.4-fold (0.14 log units), on the low side, within the range that was stated.
By their numbers in this assay, from the lowest: compound 2; then compounds 3 and 4 (each within the scatter of the next). At a limit, above all of these: compound 1.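

In this assay, methoxy in place of hydrogen on an aromatic carbon, ortho to an amino group, gives a 1.1-fold higher number from compound 3 to compound 4 (0.03 log units; within the scatter), so compound 3 and compound 4 cannot be told apart. For the compounds shown here, this is the first measured substitution at this position, and the added methoxy leaves the read-out within the scatter while the amino group stays in place. Nothing measured here gives a cause for this step.

On these data alone, whether an ethoxy or a hydroxyl group at this position would read the same stays open. So does whether methoxy would read the same with iodo in place of the amino group.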